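Working notes: predicting compound 4 from compounds 1 to 3

The compounds below may be only part of what the source reports. "The series", "measured", "known", "first", "only" and "open" are said of these compounds alone.

Measured so far in an assay on CHO cells for displacement of a labelled ligand from 5-hydroxytryptamine receptor 1B (Homo sapiens); a lower number here means a stronger inhibitor, a higher number a weaker inhibitor:
compound 1, `O=S(=O)(NCC1CCN(CCCc2c[nH]c3ccc(-n4cnnc4)cc23)CC1)c1ccccc1`, gives 60 nM
compound 2, `C[C@@H](NCC1CCN(CCCc2c[nH]c3ccc(-n4cnnc4)cc23)CC1)c1ccccc1`, gives 14 nM
compound 3, `CN(Cc1cccs1)C1CCN(CCCc2c[nH]c3ccc(-n4cnnc4)cc23)CC1`, gives 140 nM

Compound 1 stands second highest of the three numbers. The nearer step from it is a 2.3-fold higher number from compound 1 to compound 3 (0.37 log units; beyond the scatter); the farther step is a 4.3-fold lower number from compound 1 to compound 2 (0.63 log units; beyond the scatter).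

Compound 4, `CN(C1CCN(CCCc2c[nH]c3ccc(-n4cnnc4)cc23)CC1)S(=O)(=O)c1ccccc1`, has not yet been measured. It differs from compound 1 in one place: methyl(phenylsulfonyl)amino in place of ((phenylsulfonyl)amino)methyl on a saturated ring carbon. The two hold the same atoms, joined differently, so the change is a relocation of the sulfonamide nitrogen onto the saturated ring carbon together with methylation of that nitrogen.

For the measured compounds named here, two measured steps bear on this. The step of a 2.3-fold higher number from compound 1 to compound 3 (0.37 log units; beyond the scatter) likewise puts a methylated nitrogen directly on the ring carbon, though it also exchanges the phenylsulfonyl for a (thiophen-2-yl)methyl, so it is not a clean match. The step of a 10-fold higher number from compound 2 to compound 3 (1.00 log units; beyond the scatter) makes the same kind of move from a different starting amine and is larger, in the same upward direction. Both point toward a weaker number when the nitrogen moves onto the ring and loses its hydrogen-bond donor, but the sulfonyl is retained here, so the size is uncertain.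

Compound 4 is therefore expected to show a modest rise, a 2.0-fold higher number from compound 1 to compound 4 (0.30 log units; within the scatter), with an estimate of 120 nM and a range from 40 nM to 400 nM.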

Compound 4, half-maximal inhibitory concentration: 10 nM
Beside the measured number, compound 4's estimate is 12-fold (1.08 log units) above it, and the stated range ends above it.
By their numbers in this assay, from the lowest: compounds 4 and 2 (each within the scatter of the next); then compound 1; then compound 3.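

In this assay, placing a methylated nitrogen directly on the saturated ring carbon does not by itself bring a weaker number: with the phenylsulfonyl kept, the change gives a 6.0-fold lower number from compound 1 to compound 4 (0.78 log units; beyond the scatter), and the entering group carries no hydrogen-bond donor, so the donor on the leaving group is not required for a low number in this set. With the methylated nitrogen held in place, the group on it now shows a strong effect on the number, with a 14-fold lower number from compound 3 to compound 4 (1.15 log units; beyond the scatter), while the remaining step, a 1.4-fold lower number from compound 2 to compound 4 (0.15 log units; within the scatter), leaves those two compounds inseparable despite their different groups at this position. No measurement available here explains why the relocated sulfonamide gives this result.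

Still open, going by these compounds, is how much of the result belongs to the methyl on the sulfonamide nitrogen, which an ethyl group or a plain hydrogen at that nitrogen would test. Also open, on these data alone, is whether the sulfonyl itself matters at this position, as a benzoyl amide in its place would show, and whether the phenyl ring tolerates a fluoro or methoxy group.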